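The compounds below may be only part of what the source reports. "The series", "measured", "known", "first", "only" and "open" are said of these compounds alone.

Compound 1 `COc1ccc(C(=O)/C=C/c2ccccc2-c2ccc(F)cc2)cc1OC` and compound 2 `COc1ccc(C(=O)/C=C/c2ccccc2-c2ccc(F)nc2)cc1OC` share one core and differ in a single place. In a functional assay on A549 cells (Homo sapiens) for antiproliferative activity, read by sulforhodamine B assay, with a stated time of 48 h (a higher number here means a weaker inhibitor, a lower number a stronger inhibitor), compound 1 gives 7500 nM, and compound 2 gives 17000 nM. The change between them is 6-fluoropyridin-3-yl in place of 4-fluorophenyl on an aromatic carbon, and it made a step of a 2.3-fold higher number from compound 1 to compound 2 (0.36 log units; beyond the scatter).

Compound 3 `O=C(/C=C/c1ccccc1-c1ccc(F)cc1)c1cccc(O)c1` is built on a different core; how the two cores differ is not broken down here. In this assay compound 3 gives 6900 nM, a number that lies within the scatter of the number for compound 1.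

Compound 4 `O=C(/C=C/c1ccccc1-c1ccc(F)nc1)c1cccc(O)c1` is related to compound 3 by the same change, (6-fluoropyridin-3-yl in place of 4-fluorophenyl on an aromatic carbon), made at the same place as before. Among the measured compounds shown here, only one earlier example of this change is available, so the expectation for compound 4 rests on it alone. Because the earlier step of a 2.3-fold higher number from compound 1 to compound 2 (0.36 log units; beyond the scatter) was modest but beyond the scatter, the expected step here is a 2.3-fold higher number from compound 3 to compound 4 (0.37 log units; beyond the scatter). In this assay compound 4 is therefore estimated at 16000 nM, with a likely range from 8000 nM to 32000 nM.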

Compound 4, half-maximal inhibitory concentration: 6900 nM
Estimate against measurement, compound 4: 2.3-fold (0.37 log units) above; the measured number lies below the stated range.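

In this assay, the same swap of 4-fluorophenyl for 6-fluoropyridin-3-yl on the core of compound 3 gives no change at the digits printed from compound 3 to compound 4 (within the scatter). Set beside the earlier example, the two steps cannot be told apart, even though only the first lies beyond the scatter by itself: the same change on two cores in this assay, a 2.3-fold higher number (0.36 log units; beyond the scatter) from compound 1 to compound 2 and no change at the digits printed (within the scatter) from compound 3 to compound 4, 2.3-fold (0.36 log units) apart, within the scatter of two such steps. Among the compounds shown here, this shows that the swap costs little or nothing in this assay on either core, but with only two examples and such small steps, it does not show whether the change carries over with a fixed size or whether the core has any influence on it.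

The compounds shown leave open how the swap behaves on any third core, where a single further pair could help settle the question. They also leave open what other groups would do in this place, such as a pyridin-3-yl group with an amine or a methoxy group where the fluorine stands.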